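A few compounds are considered here, and "the series" means these few. Any claim that something is new, unique, unknown or untested is made for them only; others in the source may bear on it.

Compound 1 `C/C=C/C(=O)N(Cc1cccc(O)c1)c1cc(OC)c(OC)c(OC)c1`: in a functional assay on MGC-803 cells (Homo sapiens) for inhibition, read by MTT assay, with a stated time of 48 h (a higher number here means a weaker inhibitor, a lower number a stronger inhibitor), compound 1 gives 14100 nM.
Compound 2 `COC(=O)c1cc(CNc2cc(OC)c(OC)c(OC)c2)ccc1OC`: in this assay compound 2 gives 49600 nM.
Compound 3 `COc1ccc(CN(C(=O)C=C(C)C)c2cc(OC)c(OC)c(OC)c2)cc1O`: in this assay compound 3 gives 320 nM.

Of these three, compound 3 has the lowest number and is therefore the strongest inhibitor of the set; compound 1 is the nearest to it and compound 2 the furthest, and both gaps lie beyond the usual scatter of repeated measurements. Compound 4 `COc1ccc(CN(C(=O)C(C)Br)c2cc(OC)c(OC)c(OC)c2)cc1O` has not yet been measured. It differs from compound 3 in a single place: 1-bromoethyl in place of 2-methylprop-1-en-1-yl on a carbonyl carbon. For the measured compounds named here, no pair of measured compounds shares exactly this change, so the size of the step can only be guessed. Compound 3 carries the group that leaves, and its low number is the best result seen so far; compound 4 is expected to lose some of that, with a step of a 4.7-fold higher number from compound 3 to compound 4 (0.67 log units; beyond the scatter) in this assay toward weaker inhibition, although a result within the scatter would not be surprising. For compound 4 the estimated value in this assay is 1500 nM, expected to fall between 300 nM and 8000 nM.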

Compound 4, half-maximal inhibitory concentration: 120 nM
For compound 4 the middle estimate is 13-fold (1.10 log units) above the measured one; measured number below the stated range.
By their numbers in this assay, from the lowest: compound 4; then compound 3; then compound 1; then compound 2.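

At this position, on a carbonyl carbon bonded to the amide-type nitrogen, the 2-methylprop-1-en-1-yl group of compound 3 turns out not to be needed for strong inhibition. In this assay, putting 1-bromoethyl in its place gives a 2.7-fold lower number from compound 3 to compound 4 (0.43 log units; beyond the scatter), a modest gain that shows this position accepts a group with a bromine and no double bond outside the aromatic rings. Nothing among the available data explains why the number falls.

This single pair changes the bromine, the double bond and the shape of the chain together, so it cannot show which of them matters. On these data alone, a plain ethyl group, which has no bromine, or a 1-chloroethyl group at the same position would help separate these features, and how either would behave remains open.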